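Chain extension on the thioether of a chloromethyl ketone

The source may hold more compounds than are shown below. What is called first, only, known or untested is meant among the compounds shown, and "the series" means these compounds.

Measured so far:
compound 1: `CCCCCCCCCCCCCSC[C@H](NC(C)=O)C(=O)CCl` gives > 100000 nM in a functional assay on NALM-6 cells (Homo sapiens); on this read-out lower numbers stand for stronger inhibition and higher numbers for weaker inhibition.
compound 2: `CCCCCCCCCCCCCCCCSC[C@H](NC(C)=O)C(=O)CCl`; compound 2 gives 16000 nM in this assay.

In this assay the value of compound 1 is a limit, not a number, (the limit of > 100000 nM in this assay, at which 1 of the 2 values shown sits). Compound 2 therefore holds the only number shown. Compound 3 is `CCCCCCCCCCCCCCCCCCCCCCSC[C@H](NC(C)=O)C(=O)CCl`. It differs from compound 2 by hexyl in place of hydrogen on a saturated chain carbon, ten or more bonds along the chain from a sulfur. Among the compounds with values here, the one measured step at this place, an at least 6.2-fold lower number from compound 1 to compound 2 (0.79 log units; beyond the scatter), lowered the number. On that basis a further lowering of modest size is expected for compound 3, a 3.2-fold lower number from compound 2 to compound 3 (0.51 log units; beyond the scatter). Compound 3 is estimated at 5000 nM, with a range from 1000 nM to 30000 nM.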

Compound 3, half-maximal inhibitory concentration: > 100000 nM
Compound 3: only a limit was reported; the forecaster's own chance of this, stated with the estimate: 10%; at least 20-fold (1.30 log units) between middle value and limit.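

In this assay, hexyl in place of hydrogen at this place gives an at least 6.2-fold higher number from compound 2 to compound 3 (0.79 log units; beyond the scatter), the opposite direction to the earlier propyl step, so lengthening this chain does not lower the number throughout. The values of compound 1 and compound 3 are limits, the step between them cannot be read, and only compound 2 gives a number: the limit of > 100000 nM in this assay, at which 2 of the 3 values shown sit.

Open, on these data alone, is what ethyl or butyl in place of hydrogen on the chain of compound 2 would give in this assay. Also open, as far as these compounds go, is what an amine or a carboxylic acid in place of hexyl would give.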